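The compounds below may be only part of what the source reports. "The series", "measured", "known", "first", "only" and "open" are said of these compounds alone.

Compound 1 `CS(=O)(=O)c1ccc(F)cc1NCC1=NCCN1` and compound 2 `CS(=O)(=O)c1cc(F)ccc1NCC1=NCCN1` are built from the same atoms joined differently; the difference between the two cores is not broken down here. In an assay on CHO cells for binding affinity to Alpha-2B adrenergic receptor (Homo sapiens), read by radioligand binding (on this read-out lower numbers stand for stronger inhibition and higher numbers for weaker inhibition), compound 1 gives < 6310 nM, which is a limit of the assay and not a number. In this assay compound 2 gives < 6310 nM, again a limit of the assay. Compound 3 `CSc1ccc(F)cc1NCC1=NCCN1` differs from compound 1 by methylsulfanyl in place of methylsulfonyl on an aromatic carbon, and in this assay compound 3 gives 331 nM; the step that the limit leaves unreadable from compound 1 to compound 3 stays unreadable because of the limit of < 6310 nM in this assay, at which 2 of the 3 values shown sit. Compound 4 `CSc1cc(F)ccc1NCC1=NCCN1` arises from compound 2 by the same kind of change, (methylsulfanyl in place of methylsulfonyl on an aromatic carbon), the entering group here standing meta to the fluoro group rather than para to it. For compound 4 a step that the limit leaves unreadable from compound 2 to compound 4 is expected, resting on compound 3 and its 331 nM. Compound 4 is therefore estimated at 450 nM, between 100 nM and 2500 nM.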

Compound 4, inhibition constant: 851 nM
Estimate against measurement, compound 4: 1.9-fold (0.28 log units) below; the range from low to high includes it.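

No new step can be read from compound 2 to compound 4, nor from compound 1 to compound 3, because compound 2 and compound 1 each give a limit and not a number: the limit of < 6310 nM in this assay, at which 2 of the 4 values shown sit.

The compounds shown leave open how large the change from methylsulfonyl to methylsulfanyl is in either pair.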